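Trimming the Amine Substituent Down to Hydrogen

A few compounds are considered here, and "the series" means these few. Any claim that something is new, unique, unknown or untested is made for them only; others in the source may bear on it.

Measured in a functional assay on HepG2 cells (Homo sapiens) for inhibition, read by MTT assay, with a stated time of 48 h; a higher number here means a weaker inhibitor, a lower number a stronger inhibitor:
- compound 1 `CCOC(=O)C1=C(N/N=C(/Br)c2ccccc2)Nc2[nH]nc(C)c2C1c1ccc(N(C)C)cc1` gives 72000 nM
- compound 2 `CCOC(=O)C1=C(N/C=N/c2ccc([N+](=O)[O-])cc2)Nc2[nH]nc(C)c2C1c1ccc(N(C)C)cc1` gives 50900 nM
- compound 3 `CCOC(=O)C1=C(N/N=C(/Cl)C#N)Nc2[nH]nc(C)c2C1c1ccc(N(C)C)cc1` gives 23600 nM

Compound 3 stands lowest of the three: the step of a 3.1-fold lower number from compound 1 to compound 3 (0.48 log units; beyond the scatter) and the step of a 2.2-fold lower number from compound 2 to compound 3 (0.33 log units; beyond the scatter) are both beyond the scatter, while the step of a 1.4-fold lower number from compound 1 to compound 2 (0.15 log units; within the scatter) is within it, so compounds 1 and 2 cannot be ranked against each other.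

Compound 4 `CCOC(=O)C1=C(N)Nc2[nH]nc(C)c2C1c1ccc(N(C)C)cc1` carries this one step further: a hydrogen atom in place of a group of 5 heavy atoms (2 carbon, 2 nitrogen, 1 chlorine; no ring), on an amine nitrogen. The two steps that bear on it each replaced a larger group on that amine nitrogen with a smaller one and gave a modestly lower number, whereas the swap between groups of nearly equal size from compound 1 to compound 2 changed little. Removing the group entirely goes beyond anything measured, so the expectation rests on a short series and is held loosely. A further modest fall in the number is expected, though a result close to compound 3 would not surprise. Compound 4 is expected to give 15000 nM, within 5000 nM to 60000 nM, which is expected to be a step of a 1.6-fold lower number from compound 3 to compound 4 (0.20 log units; within the scatter).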

Compound 4, half-maximal inhibitory concentration: 4240 nM
Estimate against measurement, compound 4: 3.5-fold (0.55 log units) above, and the stated range ends above it.
By their numbers in this assay, from the lowest: compound 4; then compound 3; then compounds 2 and 1 (each within the scatter of the next).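

Taking the substituent off the amine nitrogen altogether matters more than any swap among the groups before it: in this assay the steps of a 17-fold lower number from compound 1 to compound 4 (1.23 log units; beyond the scatter) and a 12-fold lower number from compound 2 to compound 4 (1.08 log units; beyond the scatter) are large, and even a 5.6-fold lower number from compound 3 to compound 4 (0.75 log units; beyond the scatter) stands beyond the scatter. Compound 4, with only hydrogen there, is thus the strongest inhibitor of the four, so the trend toward smaller groups continues all the way to no group, although compounds 1 and 2 cannot be ranked within that trend. Nothing available here explains this fall in the number.

Going by these compounds, whether a small group such as methyl or acetyl on this nitrogen would keep the gain remains open. So does whether the amine itself is needed, or a hydroxyl group or a methyl group could take its place.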